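The compounds below may be only part of what the source reports. "The series", "measured", "known", "first", "only" and "open" are said of these compounds alone.

Measured in a functional assay on Vero cells (Chlorocebus sabaeus) for cytotoxicity; on this read-out lower numbers stand for higher toxicity in this test and higher numbers for lower toxicity in this test:
Compound 1 `Nc1ccc(NC(=O)COc2ccccc2)c(O)c1`: "not determined" (no result reported)
Compound 2 `Nc1ccc2oc(Cc3ccccc3)nc2c1`: > 600000 nM

Compound 1 has no single number to stand on, as its entry reads "not determined" (no result reported). Compound 2 gives > 600000 nM, which is a limit of the assay and not a number. The only reference point is therefore (the limit of > 600000 nM in this assay, at which 1 of the 2 values shown sits).

Compound 3 `O=C(COc1ccccc1)Nc1ccc([N+](=O)[O-])cc1O` has not yet been measured. The structural change is nitro in place of amino on an aromatic carbon, meta to a hydroxy group and para to a large group.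

Going by the values given here, no measured step shows what such a swap does in this assay, so any expectation here is tentative. A moderate step towards lower numbers, meaning somewhat higher toxicity, is the expected outcome, though no change beyond the scatter is also possible.

The estimated value for compound 3 is 200000 nM, with an expected range from 40000 nM to 600000 nM.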

Compound 3, half-maximal cytotoxic concentration: > 600000 nM
Compound 3 ended at the assay's limit; the forecaster's own chance of this, stated with the estimate: 35%; middle value at least 3.0-fold (0.47 log units) from the limit.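

In this assay compound 1 has the entry "not determined" (no result reported). Compound 3 gives > 600000 nM, which is a limit of the assay and not a number. Going by these compounds alone, no step from compound 1 to compound 3 can therefore be read. What nitro in place of amino does to the read-out stays open, and most values shown sit at one ceiling: the limit of > 600000 nM in this assay, at which 2 of the 3 values shown sit.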